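Tetrafluorophenyl Tail on a Cysteinyl Leukotriene Antagonist

The source may hold more compounds than are shown below. What is called first, only, known or untested is meant among the compounds shown, and "the series" means these compounds.

Compound 1, `Cc1c(CCCC(=O)O)c2cccc(/C=C/c3ccc(OCCCCc4ccccc4)cc3)c2n1CC(=O)O`, gives 4.1 nM in a functional assay on CHO-K1 cells for antagonist activity at cysteinyl leukotriene receptor 1 (Homo sapiens), read by fluorescence and calcium flux, with stated times of 30 min and 1 h (a higher number here means a weaker inhibitor, a lower number a stronger inhibitor), the higher of the two numbers recorded here. Compound 2, `Cc1c(Cl)cccc1CCCCOc1ccc(C#Cc2cccc3c(CCCC(=O)O)c(C)n(CC(=O)O)c23)cc1`, gives 0.22 nM in this assay, and the gap between the two values lies beyond the usual scatter. Compound 3, `Cc1c(CCCC(=O)O)c2cccc(/C=C/c3ccc(OCCCCc4c(F)c(F)cc(F)c4F)cc3)c2n1CC(=O)O`, differs from compound 1 by 2,3,5,6-tetrafluorophenyl in place of phenyl on a saturated chain carbon, four bonds along the chain from an oxygen on an aromatic ring. Among the compounds with values here, no measured pair shows this change, so the expectation rests only on compound 1 and its value 4.1 nM. The expected step is a 1.0-fold lower number from compound 1 to compound 3 (0.01 log units; within the scatter), which is taken to lie within the scatter, in no definite direction. Compound 3 is therefore estimated at 4 nM, with a range from 1.5 nM to 12 nM.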

Compound 3, half-maximal inhibitory concentration: 2.2 nM
Estimate against measurement, compound 3: 1.8-fold (0.26 log units) above; low and high end bracket the measured number.
By their numbers in this assay, from the lowest: compound 2; then compounds 3 and 1 (each within the scatter of the next).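

In this assay, 2,3,5,6-tetrafluorophenyl in place of phenyl on a saturated chain carbon, four bonds along the chain from an oxygen on an aromatic ring, gives a 1.9-fold lower number from compound 1 to compound 3 (0.27 log units; within the scatter). Within the data shown here, this is the first reading of this change, and it shows that this position takes the four fluorine atoms without a step beyond the scatter.

Left open is how a cyclohexyl ring or a longer chain at this place would read, and whether the same change would read alike on compound 2. Nothing measured here offers an explanation for the result.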